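The source may report more compounds than this note shows. Statements on the series, on what has been measured and on what is new or still open speak of the compounds shown alone.

Measured compounds in a functional assay on HepG2 cells (Homo sapiens) for inhibition, read by sulforhodamine B assay, with a stated time of 72 h; a lower number here means a stronger inhibitor, a higher number a weaker inhibitor:
compound 1 `C[C@H](Nc1ncnc2[nH]cnc12)c1nn(-c2cccnc2)c2ccc(F)cc12` gives 41900 nM;
compound 2 `C[C@H](Nc1ncnc2[nH]cnc12)c1nn(-c2cccc(F)c2)c2cc(F)ccc12` gives 32300 nM.

Compound 2 holds the lower of the two numbers, yet its gap to compound 1 is within the scatter, so the two are not told apart. Within the data shown here, no step between measured compounds is available for a change of this kind. Compound 3 `C[C@H](Nc1ncnc2[nH]cnc12)c1nn(-c2ccccn2)c2cc(F)ccc12` differs from compound 2 by pyridin-2-yl in place of 3-fluorophenyl on an aromatic nitrogen. Among the measured compounds shown here, with no comparable step to lean on, the expected change in this assay is small, probably none beyond the scatter, in either direction. Compound 3 is estimated at 35000 nM, range 14000 nM to 90000 nM, a step of a 1.1-fold higher number from compound 2 to compound 3 (0.03 log units; within the scatter).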

Compound 3, half-maximal inhibitory concentration: 29900 nM
For compound 3 the middle estimate is 1.2-fold (0.07 log units) above the measured one; the range from low to high includes it.
By their numbers in this assay, from the lowest: compounds 3, 2 and 1 (each within the scatter of the next).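

On the aromatic nitrogen of the five-membered ring, pyridin-2-yl in place of 3-fluorophenyl gives a 1.1-fold lower number from compound 2 to compound 3 (0.03 log units; within the scatter) in this assay. Among these compounds, this is the first readable step at this position, and swapping the carbon-only ring for one carrying a ring nitrogen and a hydrogen-bond acceptor does not separate the pair. Nothing available explains the size of this step.

Still open, going by these compounds, is whether a non-aromatic group at this nitrogen, such as a short alkyl chain or a morpholine, would move the number beyond the scatter. An amine or a carboxylic acid on the pyridin-2-yl ring is equally untested in the compounds shown here.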